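From cyclopropyl to phenyl on compound 2

A few compounds are considered here, and "the series" means these few. Any claim that something is new, unique, unknown or untested is made for them only; others in the source may bear on it.

In a functional assay on the whole organism (strain Sprague-Dawley) for inhibition, with Rattus norvegicus as the target, with a stated time of 10 min (a higher number here means that more compound is needed for the effect, a lower number that less compound is needed), compound 1 `O=C(O)c1cnc(-c2ccccc2OCc2ccccc2)[nH]c1=O` gives 5 mg/kg, whereas compound 2 `CCOC(=O)c1cnc(-c2ccccc2OCC2CC2)[nH]c1=O` gives 0.3 mg/kg, the lower of the two numbers and well beyond the scatter. Compound 3 `CCOC(=O)c1cnc(-c2ccccc2OCc2ccccc2)[nH]c1=O` has not yet been measured. It carries phenyl in place of cyclopropyl on a saturated chain carbon bound to an oxygen on an aromatic ring. For the measured compounds named here, no measured step isolates this change, so the expectation is uncertain. The expected change is a 3.3-fold higher number from compound 2 to compound 3 (0.52 log units; beyond the scatter), a moderate rise in this assay just beyond the scatter. Compound 3 is estimated at 1 mg/kg, with an expected range of 0.2 mg/kg to 4 mg/kg.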

Compound 3, dose for 50% inhibition: > 5 mg/kg
Compound 3: a limit, no number; the forecaster's own chance of this, stated with the estimate: 5%; at least 5.0-fold (0.69 log units) between middle value and limit.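

In this assay, compound 3 is reported only as a limit, not as a number: the limit of > 5 mg/kg in this assay, at which 1 of the 3 values shown sits. Even so, phenyl in place of cyclopropyl on this saturated chain carbon gives an at least 16-fold higher number from compound 2 to compound 3 (1.22 log units; beyond the scatter), the first isolated reading at this position, and it shows that, with the rest of the structure unchanged, cyclopropylmethoxy needs far less compound than benzyloxy. Ethyl in place of hydrogen on an oxygen next to a carbonyl group gives a number no lower from compound 1 to compound 3 (the limit leaves the size open). From the compounds shown here alone, how far compound 3 lies past its limit stays open. So does whether a cyclobutyl group or a longer chain in this place would keep the low number of compound 2.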